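Sulfonamide variation on the shared core: note toward compound 4

A few compounds are considered here, and "the series" means these few. Any claim that something is new, unique, unknown or untested is made for them only; others in the source may bear on it.

Measured so far:
compound 1 `CN(C)S(=O)(=O)c1ccccc1Nc1cc(-c2ccc3ccn(C)c3c2)c2nccnc2c1` gives 94 nM
compound 2 `CN1CCCC(NS(=O)(=O)c2ccccc2Nc2cc(-c3ccc4ccn(C)c4c3)c3nccnc3c2)C1` gives 59 nM
compound 3 `CN(Cc1cncnc1)S(=O)(=O)c1ccccc1Nc1cc(-c2ccc3ccn(C)c3c2)c2nccnc2c1` gives 62 nM

All three values come from an assay for inhibition of 6-phosphofructo-2-kinase/fructose-2,6-bisphosphatase 3 (Homo sapiens), read by ADP-Glo, with a stated time of 2 h; a higher number here means a weaker inhibitor, a lower number a stronger inhibitor. Compound 1 carries the highest of the three numbers, but its nearest neighbour, compound 3, and its furthest, compound 2, both sit within the scatter of it, so no ordering among the three is claimed.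

Compound 4 `Cn1cc(CNS(=O)(=O)c2ccccc2Nc2cc(-c3ccc4ccn(C)c4c3)c3nccnc3c2)cn1` has not yet been run in this assay. It differs from compound 1 in one place: ((1-methyl-1H-pyrazol-4-yl)methyl)amino in place of dimethylamino on a sulfonyl sulfur.

Among the measured compounds shown here, two measured steps bear on this change. The step of a 1.6-fold lower number from compound 1 to compound 2 (0.20 log units; within the scatter) swaps the dimethylamino on the sulfonyl sulfur for a ring-bearing amino group, as the change to compound 4 does. The step of a 1.5-fold lower number from compound 1 to compound 3 (0.18 log units; within the scatter) attaches a six-membered heteroaryl ring through a saturated chain carbon bound to the sulfonamide nitrogen, and compound 4 likewise brings an aromatic heterocycle in through such a carbon. Both steps were small and within the scatter, and the pair compound 2 versus compound 3 shows the same. No step beyond the scatter is therefore expected for compound 4 in this assay, if anything a slightly lower number, as a 1.3-fold lower number from compound 1 to compound 4 (0.13 log units; within the scatter).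

Compound 4 is estimated at 70 nM, with a range from 30 nM to 160 nM.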

Compound 4, half-maximal inhibitory concentration: 38 nM
For compound 4 the middle estimate is 1.8-fold (0.27 log units) above the measured one; low and high end bracket the measured number.
By their numbers in this assay, from the lowest: compounds 4, 2, 3 and 1 (each within the scatter of the next, the first and the last beyond it).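

In this assay, the sulfonyl sulfur position now gives a step beyond the scatter, a 2.5-fold lower number from compound 1 to compound 4 (0.39 log units; beyond the scatter), a modest one, when dimethylamino gives way to ((1-methyl-1H-pyrazol-4-yl)methyl)amino, which enters with one five-membered aromatic ring with 2 hetero atoms and 1 hydrogen-bond donor. The ring-bearing groups at this position are not separated from one another, as a 1.6-fold lower number from compound 3 to compound 4 (0.21 log units; within the scatter) and a 1.6-fold lower number from compound 2 to compound 4 (0.19 log units; within the scatter) both lie within the scatter, so the result reads as a difference from dimethylamino and not as a ranking among the ring-bearing groups. No measurement shown accounts for the step.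

Still open, from the compounds shown here alone, is whether the step needs the aromatic ring or goes with the sulfonamide hydrogen: the change to compound 4 brings in both at once. Also open, going by these compounds, is how a plain unsubstituted amino group, a benzylamino group or a morpholin-4-yl group on the sulfonyl sulfur would read in this assay.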